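Swapping bromo for phenoxy in compound 2

A few compounds are considered here, and "the series" means these few. Any claim that something is new, unique, unknown or untested is made for them only; others in the source may bear on it.

In a functional assay on HT-29 cells (Homo sapiens) for antiproliferative activity, read by sulforhodamine B assay, with a stated time of 48 h (a higher number here means a weaker inhibitor, a lower number a stronger inhibitor), compound 1 (`Cc1cccc(NS(=O)(=O)c2ccc(N3CCNC3=O)cc2)c1`) gives 110 nM and compound 2 (`O=C1NCCN1c1ccc(S(=O)(=O)Nc2cccc(Br)c2)cc1`) gives 77 nM, so these two values lie within the usual scatter of each other. Compound 3 (`O=C1NCCN1c1ccc(S(=O)(=O)Nc2cccc(Oc3ccccc3)c2)cc1`) carries phenoxy in place of bromo on an aromatic carbon, and the difference from compound 2 is phenoxy in place of bromo on an aromatic carbon. Going by the values given here, only one measured step bears on this change: a 1.4-fold lower number from compound 1 to compound 2 (0.15 log units; within the scatter), with bromo in place of methyl. Among the compounds with values here, no measured compound carries a ring at this place, so that step is a weak guide to a much larger replacement. A modest rise in the number in this assay, meaning a weaker inhibitor, is expected, though the direction remains uncertain. The expected change is a 3.2-fold higher number from compound 2 to compound 3 (0.51 log units; beyond the scatter). For compound 3, the estimated value is 250 nM, with an expected range of 50 nM to 1200 nM.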

Compound 3, half-maximal inhibitory concentration: 200 nM
Beside the measured number, compound 3's estimate is 1.3-fold (0.10 log units) above it, and the stated range covers the measured number.
By their numbers in this assay, from the lowest: compounds 2, 1 and 3 (each within the scatter of the next, the first and the last beyond it).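

this assay now has its first case of a ring at this place, and the swap from bromo to phenoxy is a modest loss (a 2.6-fold higher number from compound 2 to compound 3 (0.41 log units; beyond the scatter)). Measured against methyl, the same ring gives a step that cannot be separated from noise (a 1.8-fold higher number from compound 1 to compound 3 (0.26 log units; within the scatter)), so a group of seven heavy atoms is accepted here without a large penalty, even though compound 3 falls behind compound 2. Nothing shown here explains why phenoxy differs from bromo.

As far as these compounds go, it stays open whether the ring itself or the oxygen linking it accounts for the step, which a phenyl group attached directly or a benzyl group could help to separate. Also open, from the compounds shown here alone, is how an amine or a carboxylic acid at this place would compare with compound 2.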